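The compounds below may be only part of what the source reports. "The series", "measured", "known", "first", "only" and "open" are said of these compounds alone.

Compound 1 `Oc1cc(-c2ccccc2)ccc1C(O)(C(F)(F)F)C(F)(F)F` in an assay on isolated protein for inhibition of tyrosine-protein phosphatase non-receptor type 13 (Homo sapiens), read by spectrophotometry; a higher number here means a weaker inhibitor, a lower number a stronger inhibitor: > 500000 nM
Compound 2 `O=C(COc1ccc2cc(C(O)(C(F)(F)F)C(F)(F)F)c(O)cc2c1)Nc1ccccc1` in this assay: > 20000 nM

The value recorded for compound 1 is a limit of the assay and not a number (the limit of > 500000 nM in this assay, at which 1 of the 2 values shown sits). The value recorded for compound 2 is likewise a limit and not a number (the limit of > 20000 nM in this assay, at which 1 of the 2 values shown sits). Compound 2 therefore stands at the edge of what the assay could resolve, with no finished number to compare against, and both values shown here are limits of this kind. Compound 3 `O=C(COc1ccc2cc(C(O)(C(F)(F)F)C(F)(F)F)c(O)cc2c1)NCc1ccccc1` has not yet been measured in this assay and differs from compound 2 by benzyl in place of phenyl on an amide-type nitrogen. Within the data shown here, no step between two measured compounds is available to calibrate a change of this sort, and the expected step that the limit leaves unreadable from compound 2 to compound 3 is none beyond the scatter. For compound 3 the estimate in this assay is 30000 nM, within a range from 8000 nM to 150000 nM, and a limit rather than a number is the expected outcome.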

Compound 3, half-maximal inhibitory concentration: > 20000 nM
Compound 3: a limit, no number; the forecaster's own chance of this, stated with the estimate: 70%; the middle value is on the limit's open side.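

Among these compounds, compound 2 and compound 3 both end at a limit of the assay and not at a number, so no step between them can be read. The compounds shown leave open whether benzyl in place of phenyl on an amide-type nitrogen changes inhibition in this assay at all.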